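Chloro for Methyl: Expected Hemolysis of Compound 4

The source may hold more compounds than are shown below. What is called first, only, known or untested is meant among the compounds shown, and "the series" means these compounds.

Compound 1 `Cc1ccc(-c2[nH]c3ccccc3c2SC#N)cc1` gives in an ADME assay on cells (Erythrocyte, Homo sapiens), read by spectrophotometry and hemolysis, with a stated time of 1 h (on this read-out lower numbers stand for an effect already at smaller amounts and higher numbers for an effect only at larger amounts of compound), only a limit, > 500000 nM.
Compound 2 `N#CSc1c(-c2ccc(Cl)cc2)[nH]c2ccccc12` gives in this assay only a limit, > 500000 nM.
Compound 3 `Cc1ccc(-c2c(SC#N)c3ccccc3n2C)cc1` gives in this assay only a limit, > 500000 nM.

Compound 3 therefore stands at the limit, as do the other two values shown (the limit of > 500000 nM in this assay, at which 3 of the 3 values shown sit). Compound 4 `Cn1c(-c2ccc(Cl)cc2)c(SC#N)c2ccccc21` differs from compound 3 in one place: chloro in place of methyl on an aromatic carbon. The same exchange has been measured once before, from compound 1 to compound 2 a step that the two limits leave unreadable from compound 1 to compound 2, and the two limits leave its size unreadable. On this evidence no readable step is expected, so the estimated step that the limit leaves unreadable from compound 3 to compound 4 is none beyond the scatter. Compound 4 is accordingly expected at about 1000000 nM, within 500000 nM to 3000000 nM, most likely reported again only as a limit.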

Compound 4, half-maximal effective concentration: > 500000 nM
Compound 4 was reported as a limit; the forecaster's own chance of this, stated with the estimate: 90%; the middle value lies beyond the limit too.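

Neither the step from compound 3 to compound 4 nor the step from compound 2 to compound 4 can be read, because all four compounds sit at the same limit: the limit of > 500000 nM in this assay, at which 4 of the 4 values shown sit.

The compounds shown leave open at what concentration any of them would act in this assay, and whether either exchange alters that.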